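Swapping Cyclohexyl for Benzyl on a Shared Core

The source may hold more compounds than are shown below. What is called first, only, known or untested is meant among the compounds shown, and "the series" means these compounds.

Compound 1 `c1ccc(-c2cn3ccnc3c(-c3ccc4ncn(C5CCCCC5)c4c3)n2)cc1` carries a phenyl group on its shared core, and in a functional assay on IGROV-1 cells (Homo sapiens) for inhibition, read by sulforhodamine B assay, with a stated time of 48 h, tested at 10 uM (a lower number here means less inhibition, a higher number more inhibition at the concentration tested (going by the name of the read-out)), compound 1 gives 12%. For the measured compounds named here, compound 2 `c1cn2cc(-c3ccsc3)nc(-c3ccc4ncn(C5CCCCC5)c4c3)c2n1` differs from it in one place, and in this assay compound 2 gives 1.51%; the single measured step, a number 10.5 percentage points lower from compound 1 to compound 2 (beyond the scatter), is modest but lies beyond the scatter. Compound 3 `c1cn2cc(-c3ccc4c(c3)ncn4C3CCCCC3)nc(-c3ccc4ncn(C5CCCCC5)c4c3)c2n1` carries a second copy of the cyclohexyl-bearing fused ring system in place of the phenyl, and in this assay compound 3 gives 8.51%, a number that lies within the scatter of both compound 1 and compound 2, so no order between compound 3 and either of them can be read from these numbers.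

Compound 4 `c1ccc(Cn2cnc3ccc(-c4nc(-c5ccc6c(c5)ncn6C5CCCCC5)cn5ccnc45)cc32)cc1` is compound 3 with one change: benzyl in place of cyclohexyl on an aromatic nitrogen. Going by the values given here, no measured step touches the group on that aromatic nitrogen; the one step available, from compound 1 to compound 2, exchanges phenyl for thiophen-3-yl on an aromatic carbon, a different kind of place. There is therefore no measured basis for a shift in this assay, and the expected step of a number 0.5 percentage points lower from compound 3 to compound 4 (within the scatter) is estimated to stay within the scatter. Compound 4 is expected to give about 8% in this assay, with a range from 0% to 22%.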

Compound 4, a percentage reported as inhibition, at one concentration (the size of the read-out at that concentration, not a potency): 94.2%
For compound 4 the middle estimate is 86.2 percentage points below the measured one; the whole stated range lies below it.
By their numbers in this assay, from the lowest: compounds 2, 3 and 1 (each within the scatter of the next, the first and the last beyond it); then compound 4.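

In this assay, benzyl in place of cyclohexyl on the aromatic nitrogen gives a number 85.7 percentage points higher from compound 3 to compound 4 (beyond the scatter), which shows that the result is highly sensitive to the group at this place, a place the earlier step did not touch. The change looks small on paper: each group contains a six-membered ring of carbon only, neither has a hydrogen-bond donor or acceptor, and they differ in that the ring of benzyl is aromatic and that benzyl has 7 heavy atoms against 6 for cyclohexyl. No measurement available here explains why this exchange has such a large effect.

The compounds shown do not separate the aromatic ring from the added carbon, a question that cyclohexylmethyl, which has a non-aromatic ring with the same carbon count as benzyl, or 2-phenylethyl, a longer chain ending in the same aromatic ring, could help to answer. On these data alone, it also remains open whether a second benzyl in place of the remaining cyclohexyl of compound 4, or an amine placed on the benzyl ring, would keep this level of inhibition.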